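Chloro to bromo on the aryl ring: a halogen swap

A few compounds are considered here, and "the series" means these few. Any claim that something is new, unique, unknown or untested is made for them only; others in the source may bear on it.

Measured so far:
compound 1 `COC(=O)NC1=NC(c2ccccc2Cl)CN1` gives 50 mg/kg
compound 2 `COC(=O)NC1=NC(c2cccc(Cl)c2)CN1` gives 48 mg/kg
compound 3 `COC(=O)NC1=NC(c2ccccc2Br)CN1` gives 62 mg/kg

All three were tested in a functional assay on the whole organism for antagonist activity, with Mus musculus as the target, in the maximal electroshock model; a higher number here means that more compound is needed for the effect, a lower number that less compound is needed. Compound 1 and compound 3 differ by bromo in place of chloro on an aromatic carbon, and the step is a 1.2-fold higher number from compound 1 to compound 3 (0.09 log units; within the scatter). Compound 2 and compound 1 share the same atoms joined differently; how the two cores differ is not broken down here, and their values lie within the scatter of each other.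

Compound 4 `COC(=O)NC1=NC(c2cccc(Br)c2)CN1` is not yet measured. It differs from compound 2 by bromo in place of chloro on an aromatic carbon. This is the same kind of change as that from compound 1 to compound 3, but the place differs: there the halogen sits ortho to a large group, here meta to a large group. Beside a 1.2-fold higher number from compound 1 to compound 3 (0.09 log units; within the scatter), the step is expected to be a 1.2-fold higher number from compound 2 to compound 4 (0.08 log units; within the scatter), resting on that one earlier pair only. Compound 4 is thus estimated at 58 mg/kg in this assay, with a range from 30 mg/kg to 110 mg/kg.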

Compound 4, dose for half-maximal effect: about 68 mg/kg
Compound 4: middle estimate off by 1.2-fold (0.07 log units), on the low side; the range from low to high includes it.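

Bromo in place of chloro on an aromatic carbon gives a 1.4-fold higher number from compound 2 to compound 4 (0.15 log units; within the scatter) in this assay. Set beside the earlier pair, the two steps show no difference between the cores: the same change on two cores in this assay, a 1.2-fold higher number (0.09 log units; within the scatter) from compound 1 to compound 3 and a 1.4-fold higher number (0.15 log units; within the scatter) from compound 2 to compound 4, 1.1-fold (0.06 log units) apart, within the scatter of two such steps. This shows that the swap can be carried between these two cores without a step that rises beyond the scatter, but with both steps within the scatter, it does not show a real bromo effect on either core, and two pairs cannot speak for other cores.

The compounds shown leave open whether a group other than these two halogens, such as methoxy, nitrile or an amine, would give a step beyond the scatter on the aromatic ring. Also open, going by these compounds, is how a longer chain in place of the methyl of the carbamate would read in this assay.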